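The source may hold more compounds than are shown below. What is called first, only, known or untested is meant among the compounds shown, and "the series" means these compounds.

Measured so far in an ADME assay on microsomes from liver (Mus musculus) for metabolic stability, with a stated time of 30 min (a higher number here means that more of the compound is left, a lower number that less of the compound is left), each compound with its value:

- compound 1 `CN(C)C(=O)N[C@@H](CO)C(=O)O` gives 30%
- compound 2 `CC(C)C(=O)N[C@@H](CO)C(=O)O` gives 49%
- compound 3 `COC(=O)N[C@@H](CO)C(=O)O` gives 27%

Compound 3 sits level with compound 1 within the scatter, while compound 2 stands clearly higher than both. In compound 4 `O=C(N[C@@H](CO)C(=O)O)C1CC1`, cyclopropyl stands in place of methoxy on a carbonyl carbon (cyclopropyl in place of methoxy on a carbonyl carbon).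

Within the data shown here, three measured steps bear on this change. The closest guide is a number 22 percentage points lower from compound 2 to compound 3 (beyond the scatter), since isopropyl is the measured group nearest to cyclopropyl. Running that step backwards suggests a rise. The other two steps show the same picture from compound 1: a number 19 percentage points higher from compound 1 to compound 2 (beyond the scatter) with isopropyl, but a number 3 percentage points lower from compound 1 to compound 3 (within the scatter) with methoxy. Among the measured compounds shown here, no compound with cyclopropyl has been measured, so this remains an analogy. A modest rise in this assay is therefore expected, and the estimated step is a number 17 percentage points higher from compound 3 to compound 4 (beyond the scatter) as a result. For compound 4 the estimate is 44%, with an expected range from 30% to 58% in this measurement.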

Compound 4, percent of the compound remaining: 21%
Compound 4: middle estimate off by 23 percentage points, on the high side; measured number outside the range, below it.
By their numbers in this assay, from the lowest: compounds 4, 3 and 1 (each within the scatter of the next); then compound 2.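

In this assay, cyclopropyl in place of isopropyl on a carbonyl carbon gives a number 28 percentage points lower from compound 2 to compound 4 (beyond the scatter) and so shows that the higher number of compound 2 does not carry over to this other small carbon group. Cyclopropyl instead falls in with the polar-free reading of neither group alone: a number 6 percentage points lower from compound 3 to compound 4 (within the scatter) and a number 9 percentage points lower from compound 1 to compound 4 (within the scatter) both stay within the scatter, which leaves isopropyl as the only one of the four groups that stands apart. Nothing measured here explains the gap between isopropyl and cyclopropyl.

The compounds shown leave open whether tert-butyl, ethyl or cyclobutyl would stand with isopropyl or with cyclopropyl. They also leave open whether the gap would survive with a methyl ester in place of the carboxylic acid of the shared core.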